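Methoxy for Fluoro in a Series Without Measurable Cytotoxicity

The compounds below may be only part of what the source reports. "The series", "measured", "known", "first", "only" and "open" are said of these compounds alone.

Measured compounds:
compound 1 `Cc1ccc2c(=O)[nH]c(-c3cccc(OC(F)(F)F)c3)nc2c1`: > 50000 nM
compound 2 `Cc1ccc2nc(-c3cccc(F)c3)[nH]c(=O)c2c1`: > 50000 nM
compound 3 `CN(C)c1ccc2nc(-c3cccc4ccccc34)[nH]c(=O)c2c1`: > 50000 nM

In a functional assay on T47D cells (Homo sapiens) for cytotoxicity, read by MTT assay, with a stated time of 2 days (on this read-out lower numbers stand for stronger inhibition and higher numbers for weaker inhibition), compound 1 gives only a limit, > 50000 nM. In this assay compound 2 likewise gives only a limit, > 50000 nM, and no number. Compound 3 also stops at a limit, > 50000 nM. Among the measured compounds shown here, compound 2 therefore stands where all values shown stand, as described by the limit of > 50000 nM in this assay, at which 3 of the 3 values shown sit, with no compound separated from another.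

Compound 4 `COc1cccc(-c2nc3ccc(C)cc3c(=O)[nH]2)c1` differs from compound 2 by methoxy in place of fluoro on an aromatic carbon. Since every measured compound sits at the same limit, no step beyond the scatter is expected from compound 2 to compound 4, so a number no higher from compound 2 to compound 4 (the limit leaves the size open) is the estimated step. Compound 4 is expected at 50000 nM, within 20000 nM to 150000 nM, most likely again reported only as a limit.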

Compound 4, half-maximal inhibitory concentration: > 50000 nM
Compound 4 was reported as a limit; the forecaster's own chance of this, stated with the estimate: 80%; the middle value lies on the limit itself.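

Compound 4 ends at a limit, as compound 2 does, so no step can be read between compound 2 and compound 4: the limit of > 50000 nM in this assay, at which 4 of the 4 values shown sit. The compounds shown leave open whether any change to the shared core would give a measurable number rather than a limit.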